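Replacing the Thiazole Ring with a Tert-Butyl Group

The source may hold more compounds than are shown below. What is called first, only, known or untested is meant among the compounds shown, and "the series" means these compounds.

Compound 2 `Cc1ccc(OCC(=O)N(Cc2cccs2)c2nccs2)cc1` gives 2240 nM in an assay on HEK293 cells for agonist activity at transient receptor potential cation channel subfamily M member 8 (Homo sapiens), read by fluorescence and calcium flux, with a stated time of 15 min (on this read-out higher numbers stand for an effect only at larger amounts of compound and lower numbers for an effect already at smaller amounts), the higher of the two numbers recorded so far. For the measured compounds named here, its nearest neighbour, compound 1 `Cc1ccc(OCC(=O)N(Cc2cccs2)c2cccnc2)cc1`, gives 198 nM in this assay, and the step of an 11-fold higher number from compound 1 to compound 2 (1.05 log units; beyond the scatter) is the only measured change at this nitrogen. Compound 3 `Cc1ccc(OCC(=O)N(Cc2cccs2)C(C)(C)C)cc1` carries the next change: tert-butyl in place of 1,3-thiazol-2-yl on an amide-type nitrogen. Going by the values given here, no measured step covers an exchange of an aromatic ring for a saturated group at this position; the measured step from compound 1 to compound 2 shows only that the substituent on this nitrogen can move the read-out strongly. Without direct precedent, a further modest rise in the number is expected rather than a recovery, though the direction is uncertain. Compound 3 is therefore estimated at 3500 nM, within 900 nM to 14000 nM, which would be a step of a 1.6-fold higher number from compound 2 to compound 3 (0.19 log units; within the scatter).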

Compound 3, half-maximal effective concentration: 11000 nM
Compound 3: the middle estimate sits 3.1-fold (0.50 log units) below what was measured; measured number inside the range.
By their numbers in this assay, from the lowest: compound 1; then compound 2; then compound 3.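

In this assay the exchange of the ring for tert-butyl brings a 4.9-fold higher number from compound 2 to compound 3 (0.69 log units; beyond the scatter), and against the pyridin-3-yl group the same position shows a 56-fold higher number from compound 1 to compound 3 (1.74 log units; beyond the scatter). Among these three compounds, the two with an aromatic ring on the amide-type nitrogen give lower numbers than the one with tert-butyl, which has no ring and no hydrogen-bond acceptors, so the earlier rise from the pyridine to the thiazole was not the full span at this position. Nothing measured here explains why the number rises.

The compounds shown leave open whether the ring itself or its hetero atoms matter more. A plain phenyl or a cyclohexyl on this nitrogen would separate the two, and a pyridin-2-yl or pyridin-4-yl would show how much the place of the ring nitrogen counts.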